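Bromo for chloro, second instance on a changed core

A few compounds are considered here, and "the series" means these few. Any claim that something is new, unique, unknown or untested is made for them only; others in the source may bear on it.

Measured in a functional assay on MOLT-4 cells (Homo sapiens), with a stated time of 72 h; a higher number here means a weaker inhibitor, a lower number a stronger inhibitor:
compound 1 `O=C1Nc2ccc(Cl)cc2/C1=N/NC(=S)Nc1ccc(Cl)cc1`: 64000 nM
compound 2 `O=C1Nc2ccc(Br)cc2/C1=N/NC(=S)Nc1ccc(Cl)cc1`: 29000 nM
compound 3 `O=C1/C(=N\NC(=S)Nc2ccc(Cl)cc2)c2cc(Cl)ccc2N1Cc1ccc(F)cc1`: 48000 nM

Compound 2 differs from compound 1 by bromo in place of chloro on an aromatic carbon, and this change gave a 2.2-fold lower number from compound 1 to compound 2 (0.34 log units; beyond the scatter). Compound 3 differs from compound 1 by 4-fluorobenzyl in place of hydrogen on an amide-type nitrogen in a ring, a change that gave a 1.3-fold lower number from compound 1 to compound 3 (0.12 log units; within the scatter). Compound 4 `O=C1/C(=N\NC(=S)Nc2ccc(Cl)cc2)c2cc(Br)ccc2N1Cc1ccc(F)cc1` is not yet measured; it differs from compound 3 by bromo in place of chloro on an aromatic carbon, at a place described in the same words as for the change from compound 1 to compound 2, so it is the same change on the core of compound 3. Within the data shown here, only one earlier instance exists, so its transfer to the new core is untested. A step of about the same size, a 2.2-fold lower number from compound 3 to compound 4 (0.34 log units; beyond the scatter), is expected in this assay because the same change gave a 2.2-fold lower number from compound 1 to compound 2 (0.34 log units; beyond the scatter). Compound 4 is therefore estimated at 22000 nM in this assay, with a range from 10000 nM to 55000 nM.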

Compound 4, half-maximal inhibitory concentration: 48000 nM
Compound 4: the middle estimate sits 2.2-fold (0.34 log units) below what was measured; the range from low to high includes it.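

In this assay, bromo in place of chloro on the core of compound 3 gave no change at the digits printed from compound 3 to compound 4 (within the scatter), and the two steps for this change do not differ beyond the scatter: the same change on two cores in this assay, a 2.2-fold lower number (0.34 log units; beyond the scatter) from compound 1 to compound 2 and no change at the digits printed (within the scatter) from compound 3 to compound 4, 2.2-fold (0.34 log units) apart, within the scatter of two such steps. The 4-fluorobenzyl change gave a 1.7-fold higher number from compound 2 to compound 4 (0.22 log units; within the scatter), and its two steps agree in the same way: the same change on two cores in this assay, a 1.3-fold lower number (0.12 log units; within the scatter) from compound 1 to compound 3 and a 1.7-fold higher number (0.22 log units; within the scatter) from compound 2 to compound 4, 2.2-fold (0.34 log units) apart, within the scatter of two such steps. The bromo step is thus compatible with carrying over between the two cores, but with only two instances, one of them within the scatter, this does not establish a consistent step on either core or any other.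

Open, as far as these compounds go, is whether a nitrile or a methoxy on that aromatic carbon would move the number in this assay beyond the scatter. The same applies to a longer chain ending in an amine or a carboxylic acid in place of 4-fluorobenzyl on the amide-type nitrogen.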